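The source may hold more compounds than are shown below. What is called first, only, known or untested is meant among the compounds shown, and "the series" means these compounds.

Compound 1 `COc1ccc(-c2cn(-c3ccc(OC(F)(F)F)cc3)nn2)cc1O` and compound 2 `COc1ccc(-c2cn(-c3ccc(Oc4ccccc4)cc3)nn2)cc1O` share one core and differ in a single place. In a functional assay on MDA-MB-231 cells (Homo sapiens) for cytotoxicity, read by MTT assay (a lower number here means a stronger inhibitor, a higher number a weaker inhibitor), compound 1 gives only a limit of the assay, > 10000 nM. In this assay compound 2 likewise gives only a limit, > 10000 nM. Going by the values given here, the sole measured step, a step that the two limits leave unreadable from compound 1 to compound 2, cannot be read, and compound 2 stands at the limit, where (the limit of > 10000 nM in this assay, at which 2 of the 2 values shown sit). Compound 3 `Oc1cc(O)cc(-c2cn(-c3ccc(Oc4ccccc4)cc3)nn2)c1` is not yet measured; it differs from compound 2 by 3,5-dihydroxyphenyl in place of 3-hydroxy-4-methoxyphenyl on an aromatic carbon. Among the compounds with values here, no measured step touches this change, as the pair of compound 1 and compound 2 concerns only the group on an oxygen on an aromatic ring. Within the data shown here, the two measured values give no size for any step, so the expectation rests on compound 2 alone and on its limit. Compound 3 is therefore estimated at 15000 nM, with a range from 3000 nM to 60000 nM. The expected step is a step that the limit leaves unreadable from compound 2 to compound 3, no change beyond the scatter.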

Compound 3, half-maximal inhibitory concentration: > 10000 nM
Compound 3 ended at the assay's limit; the forecaster's own chance of this, stated with the estimate: 65%; the middle value lies beyond the limit too.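

The step from compound 2 to compound 3 cannot be read, because both compounds end at a limit rather than at a number: the limit of > 10000 nM in this assay, at which 3 of the 3 values shown sit.

The compounds shown leave open how strong any of them is in this assay, and whether 3,5-dihydroxyphenyl in place of 3-hydroxy-4-methoxyphenyl changes the result at all.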